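Changing the aryl ether on the oxygen: compound 1 to compound 3

The source may report more compounds than this note shows. Statements on the series, on what has been measured and on what is new or still open speak of the compounds shown alone.

Measured compounds:
compound 1 `CCc1nn(C)c(CO/N=C/c2c(C)nn(C)c2Oc2ccccc2F)c1Cl`: < 80%
compound 2 `COc1ccc(Oc2c(/C=N\OCc3c(Cl)c(-c4ccc(F)cc4)nn3C)c(C)nn2C)cc1`: 80%

Both compounds were tested in a functional assay on SMMC-7721 cells (Homo sapiens) for inhibition, read by MTT assay, with a stated time of 72 h, tested at 25 uM; on this read-out lower numbers stand for less inhibition and higher numbers for more inhibition at the one concentration tested (going by the name of the read-out). For compound 1 the result < 80% is a limit of the assay, not a number, so only an upper bound is known (the limit of < 80% in this assay, at which 1 of the 2 values shown sits). Compound 2 gives 80% in this assay, a plain number.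

Compound 3 `CCc1nn(C)c(CO/N=C/c2c(C)nn(C)c2Oc2ccc(I)cc2)c1Cl` has not been measured yet. It keeps the whole of compound 1 except for one exchange: 4-iodophenyl in place of 2-fluorophenyl on an oxygen on an aromatic ring. Among the measured compounds shown here, compound 2 carries a different aryl ether on that same oxygen and also differs elsewhere, so the two measured values give no step that isolates this exchange. For the measured compounds named here, no measured step is available to say how large an effect it should have.

With compound 1 known only as a limit, the step that the limit leaves unreadable from compound 1 to compound 3 is taken as an expectation of no change beyond the usual scatter. Compound 3 is therefore estimated to give 55% in this assay, within a range from 20% to 85%, with a fair chance that the assay again reports only a limit.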

Compound 3, a percentage reported as inhibition, at one concentration (the size of the read-out at that concentration, not a potency): < 80%
Compound 3: no number, only a limit; the forecaster's own chance of this, stated with the estimate: 60%; the middle value does not contradict the limit.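

In this assay compound 3 gives < 80%, which is a limit of the assay and not a number. Compound 1 is also known only as a limit, so no step can be read between compound 1 and compound 3: the limit of < 80% in this assay, at which 2 of the 3 values shown sit.

The compounds shown leave open whether 4-iodophenyl and 2-fluorophenyl on that oxygen differ in inhibition, and by how much.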